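This account rests on a few compounds, and the source may have more. Where it says the series, first, only, none or still open, it means among the compounds named here.

Measured so far:
Compound 1, `C[C@@H]1C[C@H](c2nc(-c3ccc4ccccc4n3)no2)CCN1C(=O)Nc1ccccc1Cl`: 2400 nM
Compound 2, `CC(C)c1ccccc1NC(=O)N1CCC(c2nc(-c3ccc4ccccc4n3)no2)CC1`: 480 nM

Both compounds were tested in a functional assay on Shh Light II cells (Mus musculus) for inhibition, read by a luciferase reporter; a higher number here means a weaker inhibitor, a lower number a stronger inhibitor. Within the data shown here, of the two, compound 2 gives the lower number, and the only comparison available is with compound 1, whose number is higher by a margin that lies beyond the usual scatter of this assay. Compound 2 is therefore the stronger inhibitor of the pair, as far as these two numbers show.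

Compound 3, `COc1ccccc1N(C)C(=O)N1CCC(c2nc(-c3ccc4ccccc4n3)no2)CC1`, keeps the shared core of compound 2 and is changed in one place: (2-methoxyphenyl)(methyl)amino in place of (2-isopropylphenyl)amino on a carbonyl carbon. Among the measured compounds shown here, no pair of measured compounds shows a change of this kind, so its size cannot be read from the data. A modest rise in the number, meaning weaker inhibition, is expected here, and the step from compound 2 to compound 3 is estimated as a 4.2-fold higher number from compound 2 to compound 3 (0.62 log units; beyond the scatter).

For compound 3 the expected value in this assay is 2000 nM, with a likely range from 600 nM to 7000 nM.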

Compound 3, half-maximal inhibitory concentration: 3100 nM
The estimate for compound 3 lay 1.6-fold (0.19 log units) below the measured number; the measured number falls inside the stated range.
By their numbers in this assay, from the lowest: compound 2; then compounds 1 and 3 (each within the scatter of the next).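

In this assay, the group on the carbonyl carbon proves to matter: putting (2-methoxyphenyl)(methyl)amino in place of (2-isopropylphenyl)amino gives a 6.5-fold higher number from compound 2 to compound 3 (0.81 log units; beyond the scatter), so compound 3 is the weaker inhibitor of this pair. The entering group differs in two ways at once, with methoxy instead of isopropyl on the aromatic ring and a methyl on the nitrogen instead of the amide hydrogen, so this single step cannot show which difference carries the loss. No measurement at hand explains the drop.

Still open, from the compounds shown here alone, is how (2-methoxyphenyl)amino, which keeps the amide hydrogen, or (2-isopropylphenyl)(methyl)amino, which keeps the isopropyl, would behave, since either would separate the two differences. Also open, going by these compounds, is whether a larger group on that nitrogen, such as ethyl, would behave like methyl.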